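From a Chlorinated Amide to a Urea

A few compounds are considered here, and "the series" means these few. Any claim that something is new, unique, unknown or untested is made for them only; others in the source may bear on it.

Among the compounds with values here, in a functional assay on HT-1080 cells (Homo sapiens) for antiproliferative activity, read by sulforhodamine B assay, with a stated time of 48 h (a lower number here means a stronger inhibitor, a higher number a weaker inhibitor), compound 2 `O=C(CCCCl)Nc1ccc(S(=O)(=O)Oc2ccccc2I)cc1` gives 12000 nM, the higher of the two numbers measured so far. Compound 1 `CCCC(=O)Nc1ccc(S(=O)(=O)Oc2ccccc2I)cc1` gives 2000 nM, and the step of a 6.0-fold higher number from compound 1 to compound 2 (0.78 log units; beyond the scatter) was modest. Compound 3 `CCNC(=O)Nc1ccc(S(=O)(=O)Oc2ccccc2I)cc1` carries ethylamino in place of 3-chloropropyl on a carbonyl carbon. Within the data shown here, this removes the chlorine that separates compound 2 from compound 1, yet it also shortens the chain and brings in a nitrogen bearing a hydrogen, a change no measured pair covers. The number for compound 3 is expected to fall, by roughly a 4.0-fold lower number from compound 2 to compound 3 (0.60 log units; beyond the scatter). The estimate for compound 3 is 3000 nM, with a range from 800 nM to 12000 nM.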

Compound 3, half-maximal inhibitory concentration: 140 nM
Estimate against measurement, compound 3: 21-fold (1.33 log units) above; the whole stated range lies above it.
By their numbers in this assay, from the lowest: compound 3; then compound 1; then compound 2.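

In this assay, the group on this carbonyl carbon matters far more than the chlorine step suggested: ethylamino in place of 3-chloropropyl gives an 86-fold lower number from compound 2 to compound 3 (1.93 log units; beyond the scatter) and ethylamino in place of propyl gives a 14-fold lower number from compound 1 to compound 3 (1.15 log units; beyond the scatter) in this series. Losing the chlorine is therefore not the whole story, since compound 1 has no chlorine and compound 3 still stands well below it. Nothing available here explains the change. Still open, as far as these compounds go, is whether a methylamino or a propylamino group would give a lower or higher number, and what an ethoxy group, with oxygen in place of the nitrogen, would give.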